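A few compounds are considered here, and "the series" means these few. Any claim that something is new, unique, unknown or untested is made for them only; others in the source may bear on it.

Measured in a functional assay on LS174T cells (Homo sapiens) for inhibition, read by MTT assay, with a stated time of 72 h; on this read-out higher numbers stand for weaker inhibition and lower numbers for stronger inhibition:
Compound 1 `CCc1ccc(C(=O)/C=C/C(=O)O)cc1` gives 21000 nM.
Compound 2 `Cc1cc(C2CCCCC2)c(C)cc1C(=O)/C=C/C(=O)O` gives 6640 nM.

Among these two, compound 1 stands highest in this assay, and its gap to compound 2 lies beyond the scatter. Compound 3 `O=C(O)/C=C/C(=O)c1ccc(Br)cc1` is not yet measured. It differs from compound 1 by bromo in place of ethyl on an aromatic carbon. For the measured compounds named here, no measured pair shows what this exchange does, so the expectation rests on the change alone: a step of no size beyond the scatter in this assay, a 1.2-fold lower number from compound 1 to compound 3 (0.07 log units; within the scatter), is expected. Compound 3 is therefore estimated at 18000 nM, with a range from 8000 nM to 40000 nM.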

Compound 3, half-maximal inhibitory concentration: 27100 nM
The estimate for compound 3 lay 1.5-fold (0.18 log units) below the measured number; low and high end bracket the measured number.
By their numbers in this assay, from the lowest: compound 2; then compounds 1 and 3 (each within the scatter of the next).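

Replacing ethyl with bromo on this aromatic carbon gives a 1.3-fold higher number from compound 1 to compound 3 (0.11 log units; within the scatter) in this assay. At this position, para to a group of 7 heavy atoms, the assay therefore does not tell the two groups apart, even though bromo has one heavy atom and ethyl has two. No measurement shown here accounts for this result.

On these data alone, it remains open whether a longer chain, a methoxy group or an amine on this carbon would give a step beyond the scatter. A single exchange also leaves open how other groups on the shared core would behave.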